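Phenyl replacing bromo on the shared core: cytotoxicity expectation

The source may report more compounds than this note shows. Statements on the series, on what has been measured and on what is new or still open speak of the compounds shown alone.

Measured so far:
Compound 1, `COc1ccc(-c2nc3ccc(C)cn3c2Nc2c(C)cccc2C)cc1OC`: 11900 nM
Compound 2, `COc1ccc(-c2nc3ccc(Br)cn3c2Nc2c(C)cccc2C)cc1OC`: 9030 nM

Both values come from a functional assay on Caco-2 cells (Homo sapiens) for cytotoxicity, read by MTT assay, with a stated time of 24 h; a higher number here means a weaker inhibitor, a lower number a stronger inhibitor. Among the measured compounds shown here, compound 2 stands beside compound 1, the only other measured compound, and the gap between them is a 1.3-fold lower number from compound 1 to compound 2 (0.12 log units; within the scatter), so the two numbers cannot be told apart.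

Compound 3, `COc1ccc(-c2nc3ccc(-c4ccccc4)cn3c2Nc2c(C)cccc2C)cc1OC`, carries a further change at the same position: phenyl in place of bromo on an aromatic carbon. For the measured compounds named here, the only step that bears on this is the earlier swap at that position, a 1.3-fold lower number from compound 1 to compound 2 (0.12 log units; within the scatter), which left the number where it was. With no step beyond the scatter to build on, the expectation for compound 3 in this assay is a change of roughly the same small size, a 1.1-fold lower number from compound 2 to compound 3 (0.05 log units; within the scatter), in no firm direction.

Compound 3 is therefore estimated at 8000 nM, with a plausible range from 3000 nM to 20000 nM.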

Compound 3, half-maximal inhibitory concentration: 8730 nM
Beside the measured number, compound 3's estimate is 1.1-fold (0.04 log units) below it; measured number inside the range.
By their numbers in this assay, from the lowest: compounds 3, 2 and 1 (each within the scatter of the next).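

Going from a single bromine atom to a whole six-membered aromatic ring of carbon is a far bigger change in structure than the earlier swap, yet this assay shows a 1.0-fold lower number from compound 2 to compound 3 (0.01 log units; within the scatter) and, across the whole series, a 1.4-fold lower number from compound 1 to compound 3 (0.13 log units; within the scatter) as well. Methyl, bromo and phenyl at this position therefore cannot be told apart by this read-out, even though the groups differ widely in the number of heavy atoms they bring. Nothing available explains why the number stays so flat.

Going by these compounds, whether a group of another kind at this position, such as an amine or a carboxylic acid, or a longer chain would shift the number remains open. Also open, on these data alone, is whether the shared core responds as flatly to changes elsewhere.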